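Aryl swap on the shared core, single-point kinase binding

The source may hold more compounds than are shown below. What is called first, only, known or untested is meant among the compounds shown, and "the series" means these compounds.

Compound 2 `CCCS(=O)(=O)Nc1ccc(F)c(C(=O)c2n[nH]c3ncc(-c4ccc(OC)cc4Cl)cc23)c1F` is the reference point. Going by the values given here, in an assay for binding affinity to dual specificity mitogen-activated protein kinase kinase 4 (Homo sapiens), read by KINOMEscan, tested at 100 nM (a lower number here means a stronger effect, a higher number a weaker effect of the compound at the concentration tested), compound 2 gives 5.3%, numerically the lower of the two numbers measured so far. Among the compounds with values here, its only neighbour is compound 1 `CCCS(=O)(=O)Nc1ccc(F)c(C(=O)c2n[nH]c3ncc(-c4cccc(C)c4)cc23)c1F`, which in this assay gives 15%; the step of a number 9.7 percentage points lower from compound 1 to compound 2 (within the scatter) lies within the scatter, so the two values cannot be ordered.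

Compound 3 `CCCS(=O)(=O)Nc1ccc(F)c(C(=O)c2n[nH]c3ncc(-c4ccc(C(N)=O)cc4)cc23)c1F` has not yet been measured. Against compound 2 the change is 4-carbamoylphenyl in place of 2-chloro-4-methoxyphenyl on an aromatic carbon. Within the data shown here, only one measured step bears on it, a number 9.7 percentage points lower from compound 1 to compound 2 (within the scatter), which also exchanged the whole aryl group on the same aromatic carbon and stayed within the scatter. Among the measured compounds shown here, nothing measured so far speaks to a 4-carbamoylphenyl group at this place, so no step beyond the scatter in this assay is expected, but the range must stay wide. Compound 3 is expected to give 12%, with a range from 3% to 35%. The expected step is therefore a number 6.7 percentage points higher from compound 2 to compound 3 (within the scatter).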

Compound 3, a percentage reported as activity, at one concentration (the size of the read-out at that concentration, not a potency): 0.15%
Compound 3: the middle estimate sits 11.9 percentage points above what was measured; the measured number lies below the stated range.
By their numbers in this assay, from the lowest: compounds 3, 2 and 1 (each within the scatter of the next, the first and the last beyond it).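

In this assay, going by these compounds alone, the aromatic carbon of the shared core now carries 4-carbamoylphenyl, the first group with a hydrogen-bond donor, and the exchange for 2-chloro-4-methoxyphenyl, with the same count of heavy atoms, gives a number 5.2 percentage points lower from compound 2 to compound 3 (within the scatter) and so separates neither group from the other. Within the data shown here, the exchange for 3-methylphenyl gives a number 14.9 percentage points lower from compound 1 to compound 3 (beyond the scatter) and is the first step to pass the scatter, which shows that the aryl group at this place can move the read-out, though only modestly, and that the carbamoyl-bearing ring is compatible with a low number. Nothing available explains this difference between the aryl groups.

Going by these compounds, whether the hydrogen-bond donor of the carbamoyl group matters remains open, as a 4-carboxyphenyl, 4-aminophenyl or 4-(N-methylcarbamoyl)phenyl group at the same aromatic carbon would be needed to test this. The single-concentration read-outs also give no potency, and with values this close to the low end, further gains among compounds like compound 2 and compound 3 would be hard to separate without a full concentration series.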